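Removal of a ring methyl: notes on compounds 1 to 4

The source may report more compounds than this note shows. Statements on the series, on what has been measured and on what is new or still open speak of the compounds shown alone.

Measured so far:
compound 1, `COc1ccc(C2=NN(C(=O)c3ccc(C)nc3Cl)C(c3ccc(OCc4ccccc4)cc3)C2)cc1`: 10500 nM
compound 2, `COc1ccc(C2=NN(C(=O)c3cccnc3Cl)C(c3ccc(OCc4ccccc4)cc3)C2)cc1`: 9150 nM
compound 3, `Cc1ccc(C(=O)N2N=C(c3ccc(Cl)cc3)CC2c2ccc(Cl)cc2)c(Cl)n1`: 8870 nM

All three were run in a functional assay on WM 266-4 cells (Homo sapiens) for antiproliferative activity, read by MTT assay, with a stated time of 24 h; a higher number here means a weaker inhibitor of growth, a lower number a stronger inhibitor of growth. Compound 1 and compound 2 share a core and differ only by hydrogen in place of methyl on an aromatic carbon. That change gave a 1.1-fold lower number from compound 1 to compound 2 (0.06 log units; within the scatter), so the two values cannot be told apart. Compound 3 carries a different core; the difference between the two cores is not broken down here. Its value sits within the scatter of both compound 1 and compound 2, and no order among the three can be read from these numbers.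

Compound 4, `O=C(c1cccnc1Cl)N1N=C(c2ccc(Cl)cc2)CC1c1ccc(Cl)cc1`, is not yet measured. It differs from compound 3 by hydrogen in place of methyl on an aromatic carbon. The place of the change is described in the same words as the change from compound 1 to compound 2, so this is the same change made on a second core. Going by the values given here, the only evidence on its size is the single measured pair, which showed no movement beyond the scatter. Whether the second core responds in the same way is not known from these data.

The expected step is a 1.1-fold lower number from compound 3 to compound 4 (0.04 log units; within the scatter), estimated as small because the same change gave a 1.1-fold lower number from compound 1 to compound 2 (0.06 log units; within the scatter) on the first core. For compound 4 the estimate in this assay is 8000 nM, with an expected range from 4000 nM to 16000 nM.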

Compound 4, concentration for 50% growth inhibition: 3580 nM
Beside the measured number, compound 4's estimate is 2.2-fold (0.35 log units) above it; measured number outside the range, below it.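

In this assay, hydrogen in place of methyl, read as 2-chloro-6-methylpyridin-3-yl to 2-chloropyridin-3-yl, gave a 2.5-fold lower number from compound 3 to compound 4 (0.39 log units; beyond the scatter), while the same change on the first core gave a 1.1-fold lower number from compound 1 to compound 2 (0.06 log units; within the scatter). Set side by side, the two steps cannot be called different: the same change on two cores in this assay, a 1.1-fold lower number (0.06 log units; within the scatter) from compound 1 to compound 2 and a 2.5-fold lower number (0.39 log units; beyond the scatter) from compound 3 to compound 4, 2.2-fold (0.33 log units) apart, within the scatter of two such steps. Neither pair shows a higher number after the change, and the two results fit one modest step carried between the cores, but two pairs do not show that the step has the same size on both cores, nor that the core of compound 3 responds more strongly than the core of compound 1.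

The compounds shown hold only methyl or hydrogen at this place next to the ring nitrogen, so it stays open how a longer chain, an amine or a carboxylic acid there would move the number. As far as these compounds go, it also stays open whether the step would hold on a third core or in any other cell line.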